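Compound 3 to compound 4: fluoro for carbamoyl

The compounds below may be only part of what the source reports. "The series", "measured", "known", "first", "only" and "open" are said of these compounds alone.

In an ADME assay on HepG2 cells (Homo sapiens) for cytotoxicity, with a stated time of 72 h (on this read-out higher numbers stand for an effect only at larger amounts of compound and lower numbers for an effect already at smaller amounts), compound 1 `Cc1cc(NC(=O)Nc2ccc(C(C)(C)C)cc2)c2ccccc2n1` gives 17000 nM. Compound 2 `COc1ccc(NC(=O)Nc2cc(C)nc3ccccc23)cc1OC` reads > 25000 nM, which is a limit and not a number. Compound 3 `Cc1cc(NC(=O)Nc2ccccc2C(N)=O)c2ccccc2n1` also stands only at a limit, > 25000 nM. Across the series the picture so far is the limit of > 25000 nM in this assay, at which 2 of the 3 values shown sit.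

Compound 4 `Cc1cc(NC(=O)Nc2ccccc2F)c2ccccc2n1` differs from compound 3 as follows: fluoro in place of carbamoyl on an aromatic carbon. Fluoro replaces carbamoyl on an aromatic carbon, ortho to a large group. Within the data shown here, no measured pair isolates this change. Among the measured compounds shown here, compound 1, at 17000 nM, is the only numerical reading, so little or no step is expected in this assay, with any move expected towards lower values. The expected step is a number no higher from compound 3 to compound 4 (the limit leaves the size open). For compound 4 the estimate is 25000 nM, with an expected range of 12000 nM to 50000 nM.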

Compound 4, half-maximal effective concentration: > 25000 nM
Compound 4 ended at the assay's limit; the forecaster's own chance of this, stated with the estimate: 55%; the middle value sits exactly at the limit.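

Compound 3 and compound 4 both stand only at a limit in this assay, so no step can be read between them. As far as these compounds go, whether fluoro in place of carbamoyl on an aromatic carbon shifts this read-out at all stays open.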